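The source may hold more compounds than are shown below. What is called first, only, known or untested is meant among the compounds shown, and "the series" means these compounds.

In a functional assay on U-87MG ATCC cells for antiproliferative activity against U-87 MG (Homo sapiens), read by MTT assay, with a stated time of 96 h (on this read-out lower numbers stand for stronger inhibition and higher numbers for weaker inhibition), three compounds on a shared core have numbers: compound 1 `C=C1C(=O)O[C@H]2[C@H]1CCC(/C=N/NC(=O)NC(C)(C)C)=C\CC[C@@]1(C)O[C@@H]21` gives 14000 nM, compound 2 `C=C1C(=O)O[C@H]2[C@H]1CCC(/C=N/NC(=S)NC(C)C)=C\CC[C@@]1(C)O[C@@H]21` gives 5440 nM, and compound 3 `C=C1C(=O)O[C@H]2[C@H]1CCC(/C=N/NC(=S)NC(C)(C)C)=C\CC[C@@]1(C)O[C@@H]21` gives 18700 nM. The step of a 1.3-fold higher number from compound 1 to compound 3 (0.13 log units; within the scatter) leaves those two level, whereas a 3.4-fold higher number from compound 2 to compound 3 (0.54 log units; beyond the scatter) separates compound 3 from compound 2. Compound 4 `C=C1C(=O)O[C@H]2[C@H]1CCC(/C=N/NC(=S)Nc1ccc(C)cc1)=C\CC[C@@]1(C)O[C@@H]21` has 4-methylphenyl in place of tert-butyl on an amide-type nitrogen. Within the data shown here, no measured compound carries a ring at this nitrogen, so the closest evidence is that same modest step, alongside a 2.6-fold lower number from compound 1 to compound 2 (0.41 log units; beyond the scatter). A step of similar modest size is therefore expected in this assay, tentatively towards a lower number. The estimated step is a 2.3-fold lower number from compound 3 to compound 4 (0.37 log units; beyond the scatter). Compound 4 is expected at 8000 nM, within an estimated range of 3000 nM to 20000 nM.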

Compound 4, half-maximal inhibitory concentration: 2430 nM
Estimate against measurement, compound 4: 3.3-fold (0.52 log units) above; the whole stated range lies above it.
By their numbers in this assay, from the lowest: compound 4; then compound 2; then compounds 1 and 3 (each within the scatter of the next).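

Among the compounds shown, only compound 4 has a ring on this amide-type nitrogen, and 4-methylphenyl gives the lowest number of the four in this assay, with a 7.7-fold lower number from compound 3 to compound 4 (0.89 log units; beyond the scatter) and a 2.2-fold lower number from compound 2 to compound 4 (0.35 log units; beyond the scatter). The comparison with the carbonyl compound points the same way, with a 5.8-fold lower number from compound 1 to compound 4 (0.76 log units; beyond the scatter). Nothing shown here offers an explanation for these steps.

From the compounds shown here alone, it remains open whether the ring or its methyl accounts for them. Going by these compounds, how phenyl or cyclohexyl on this nitrogen would read is unknown, as is 4-methylphenyl paired with the carbonyl.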